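The source may hold more compounds than are shown below. What is called first, only, known or untested is meant among the compounds shown, and "the series" means these compounds.

Compound 1 `CCNC(=O)c1noc(-c2cc(C(C)C)c(O)cc2O)c1-c1cc(CN(C)C)no1` is the reference point of this small set. In a functional assay on A2780 cells (Homo sapiens) for inhibition (a higher number here means a weaker inhibitor, a lower number a stronger inhibitor), compound 1 gives 31 nM, the lowest of the two numbers in hand, with compound 2 `CCNC(=O)c1noc(-c2cc(C(C)C)c(O)cc2O)c1-c1cc(CN2CCCC2)no1` closest to it at 55 nM. Compound 3 `CCNC(=O)c1noc(-c2cc(C(C)C)c(O)cc2O)c1-c1cc(CN2CCN(C)CC2)no1` belongs to the same series, but in this assay compound 3 is recorded as "not determined" (no result reported). Within the data shown here, the only measured step, a 1.8-fold higher number from compound 1 to compound 2 (0.25 log units; within the scatter), exchanges the amine carried on the chain of the outer ring and leaves the number essentially where it was.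

Compound 4 `CCNC(=O)c1noc(-c2cc(C(C)C)c(O)cc2O)c1-c1ccn(C(C)C)n1` departs from compound 1 more deeply: 1-isopropyl-1H-pyrazol-3-yl in place of 3-((dimethylamino)methyl)-1,2-oxazol-5-yl on an aromatic carbon. This change removes the outer ring of compound 1 together with its chain and amine and brings in a different ring with an isopropyl group on a ring nitrogen. The step from compound 1 to compound 2 bears on it only loosely, since that step touched the chain amine alone and stayed within the scatter, whereas here the whole ring is exchanged. Among the measured compounds shown here, with no measured step of this kind, he expects a loss of potency in this assay, moderate in size, as a 3.9-fold higher number from compound 1 to compound 4 (0.59 log units; beyond the scatter). Compound 4 is therefore estimated at 120 nM, within a range from 30 nM to 600 nM.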

Compound 4, half-maximal inhibitory concentration: 45 nM
Compound 4: the middle estimate sits 2.7-fold (0.43 log units) above what was measured; the range from low to high includes it.
By their numbers in this assay, from the lowest: compounds 1, 4 and 2 (each within the scatter of the next).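

The exchange of the whole outer ring gives a 1.5-fold higher number from compound 1 to compound 4 (0.16 log units; within the scatter) in this assay and so does not separate the two compounds. This position, on an aromatic carbon next to the ring atom that bears an ethylcarbamoyl group, therefore tolerates more than the change of chain amine seen before: compound 4 carries no amine at all, and its number still stays within the scatter of that of compound 1. No measurement given here accounts for this.

The compounds shown leave open what the isopropyl group on the ring nitrogen of compound 4 contributes, as a methyl or a cyclopropyl group in its place would show. They also leave open whether a dimethylaminomethyl chain on the pyrazole ring would change the number in this assay at all.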